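The source may hold more compounds than are shown below. What is called first, only, known or untested is meant among the compounds shown, and "the series" means these compounds.

Measured compounds in an assay on membranes from uterus for displacement of a labelled ligand from Angiotensin type II receptor (Sus scrofa), with a stated time of 1.5 h; on this read-out lower numbers stand for stronger inhibition and higher numbers for weaker inhibition:
compound 1 `CCCCOC(=O)NS(=O)(=O)c1sc(CC(C)C)cc1-c1ccc(Cc2nccs2)cc1` gives 3.2 nM.
compound 2 `CCCCOC(=O)NS(=O)(=O)c1sc(CC(C)C)cc1-c1ccc(C(=O)c2ncco2)cc1` gives 13.8 nM.
compound 3 `CCCCOC(=O)NS(=O)(=O)c1sc(CC(C)C)cc1-c1ccc(CN2C(=O)CCC2=O)cc1` gives > 10000 nM, which is a limit of the assay and not a number (the limit of > 10000 nM in this assay, at which 1 of the 3 values shown sits).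

Compound 3 thus stands at the limit of this assay, the weakest point among the three values shown. Compound 4 `CCCCOC(=O)NS(=O)(=O)c1sc(CC(C)C)cc1-c1ccc(Cn2cnc(C(F)(F)F)c2)cc1` differs from it by 4-(trifluoromethyl)-1H-imidazol-1-yl in place of 2,5-dioxopyrrolidin-1-yl on a saturated chain carbon bound to an aromatic carbon. Going by the values given here, the steps that bear on this change are an at least 3100-fold higher number from compound 1 to compound 3 (3.49 log units; beyond the scatter) and an at least 720-fold higher number from compound 2 to compound 3 (2.86 log units; beyond the scatter), both large and both leading toward compound 3; the change to compound 4 runs the other way, restoring an aromatic five-membered ring on the saturated chain carbon, as in compound 1. A large downward step is therefore expected for compound 4, an at least 500-fold lower number from compound 3 to compound 4 (2.69 log units; beyond the scatter) in this assay. Compound 4 is estimated at 20 nM, with a range of 3 nM to 200 nM.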

Compound 4, inhibition constant: 7.3 nM
Compound 4: the middle estimate sits 2.7-fold (0.44 log units) above what was measured; low and high end bracket the measured number.
By their numbers in this assay, from the lowest: compound 1; then compounds 4 and 2 (each within the scatter of the next). At a limit, above all of these: compound 3.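

With 4-(trifluoromethyl)-1H-imidazol-1-yl in place of 2,5-dioxopyrrolidin-1-yl on the saturated chain carbon, strong binding returns: an at least 1300-fold lower number from compound 3 to compound 4 (3.13 log units; beyond the scatter). This place therefore accepts an aromatic ring other than 1,3-thiazol-2-yl, at a modest cost: a 2.3-fold higher number from compound 1 to compound 4 (0.36 log units; beyond the scatter), while the comparison with the oxazolyl ketone gives a 1.9-fold lower number from compound 2 to compound 4 (0.28 log units; within the scatter). The value of compound 3 is a limit and not a number: the limit of > 10000 nM in this assay, at which 1 of the 4 values shown sits.

On these data alone, what the trifluoromethyl group itself contributes remains open; a methyl group or a carboxylic acid on the same imidazole ring would separate it from the ring.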